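A few compounds are considered here, and "the series" means these few. Any claim that something is new, unique, unknown or untested is made for them only; others in the source may bear on it.

Compound 1 (`CCNC(=O)CCc1cccc2c1B(O)OC2`), with ethyl on the amide nitrogen, sits at > 100000 nM in a functional assay on HCT-116 cells (Homo sapiens) for antiproliferative activity, read by MTT assay, with a stated time of 72 h (on this read-out higher numbers stand for weaker inhibition and lower numbers for stronger inhibition), and this is a limit, not a number. Compound 2 (`O=C(CCc1cccc2c1B(O)OC2)NC1CCCCC1`), with cyclohexyl in that place, reads > 100000 nM in this assay and this too is a limit. Among the measured compounds shown here, compound 3 (`Cc1ccc(NC(=O)CCc2cccc3c2B(O)OC3)cc1`), with 4-methylphenyl on the same nitrogen, gives 4500 nM as the only actual number so far.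

Compound 4 (`O=C(CCc1cccc2c1B(O)OC2)Nc1ccc([N+](=O)[O-])cc1`) keeps all of compound 3 except for one group, with nitro in place of methyl on an aromatic carbon, para to a large group. The change counts as follows: nitro in place of methyl on an aromatic carbon and nothing else differs.

The measured steps nearest to it are an at least 22-fold lower number from compound 1 to compound 3 (1.34 log units; beyond the scatter) and an at least 22-fold lower number from compound 2 to compound 3 (1.34 log units; beyond the scatter) and both are large, but both swap the whole group on the nitrogen. The step that the two limits leave unreadable from compound 1 to compound 2 adds nothing here. For the measured compounds named here, no measured step alters a group on the aromatic ring itself, so the data give no direction for this change. Compound 4 retains the ring that came with the drop in compound 3 to 4500 nM and is therefore expected to stay near it.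

The estimated step is a 1.1-fold higher number from compound 3 to compound 4 (0.05 log units; within the scatter) and no move beyond the scatter is expected. Compound 4 is expected at 5000 nM with an estimated range from 1500 nM to 20000 nM in this assay as the likely outcome.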

Compound 4, half-maximal inhibitory concentration: > 100000 nM
Compound 4: no number, only a limit; the forecaster's own chance of this, stated with the estimate: 10%; middle value at least 20-fold (1.30 log units) from the limit.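

Replacing methyl with nitro on an aromatic carbon, para to a large group, is the only change to the ring on the amide nitrogen among the compounds shown, and in this assay it gives an at least 22-fold higher number from compound 3 to compound 4 (1.34 log units; beyond the scatter). This shows that the aromatic ring on the nitrogen is not enough on its own to keep a measurable reading in this series: compound 4 retains that ring, yet its result is a limit, as are those of compound 1 and compound 2, so the group at this position also counts. The step is a bound and not a full measure, and how far compound 4 lies past the limit cannot be told: the limit of > 100000 nM in this assay, at which 3 of the 4 values shown sit.

With only methyl and nitro shown at this position, it remains open whether an amine, a methoxy group or a chlorine there would hold the reading of compound 3 or also reach the limit. Also open, from the compounds shown here alone, is whether a longer chain between the shared core and the amide carbonyl would alter the reading of compound 3.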